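The source may hold more compounds than are shown below. What is called first, only, known or untested is meant among the compounds shown, and "the series" means these compounds.

Measured so far in a functional assay on the whole organism (strain albino) for inhibition, with Rattus norvegicus as the target, read by paw edema, with a stated time of 3 h, at a dose of 0.28 mmol/kg by the oral route; a lower number here means less inhibition, a higher number more inhibition at the dose given (going by the name of the read-out):

compound 1 `C=CCn1c(SCC(=O)c2ccccc2)nnc1-c1ccccc1` gives 70%
compound 2 `O=C(CSc1nnc(-c2ccccc2)n1-c1ccccc1)c1ccccc1` gives 64%
compound 3 `C=CCn1c(SC/C(=N/O)c2ccccc2)nnc1-c1cc(OC)c(OC)c(OC)c1` gives 70%

Compound 1 and compound 2 differ in one place: phenyl in place of allyl on an aromatic nitrogen. In this assay this gave a number 6 percentage points lower from compound 1 to compound 2 (within the scatter), a step that stays within the scatter. Compound 3 carries a different core from compound 1; the difference between the two cores is not broken down here. In this assay compound 3 sits level with compound 1 at the digits printed, and its gap to compound 2 is also within the scatter.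

Compound 4 `COc1cc(-c2nnc(SC/C(=N/O)c3ccccc3)n2-c2ccccc2)cc(OC)c1OC` is not yet measured. It differs from compound 3 by phenyl in place of allyl on an aromatic nitrogen. For the measured compounds named here, this is the same kind of change as the one from compound 1 to compound 2, though the surroundings differ: in compound 3 the ring nitrogen is next to two ring atoms that each bear a large group, whereas in compound 1 it is next to the ring atom that bears a large group and next to the ring atom that bears a phenyl group (6 heavy atoms). Resting on the near-flat step from compound 1 to compound 2, compound 4 is expected to show a step of a number 5 percentage points lower from compound 3 to compound 4 (within the scatter) in this assay, within the scatter. Compound 4 is therefore estimated at 65%, likely between 52% and 77%.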

Compound 4, a percentage reported as inhibition, in the whole organism at one dose (the size of the read-out at that dose, not a potency): 64%
Estimate against measurement, compound 4: 1 percentage points above; measured number inside the range.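

In this assay, phenyl in place of allyl on the aromatic nitrogen gives a number 6 percentage points lower from compound 3 to compound 4 (within the scatter), and this step can be set beside the earlier one on the other core: the same change on two cores in this assay, a number 6 percentage points lower (within the scatter) from compound 1 to compound 2 and a number 6 percentage points lower (within the scatter) from compound 3 to compound 4, 0 percentage points apart, within the scatter of two such steps

Across the core of compound 1 and the core of compound 3, the change therefore reads the same, and nothing in these two pairs suggests that the core alters its outcome at this dose and time. Both steps stay within the scatter, however, so they do not establish a real effect of shared size, and two pairs say nothing about how the change would behave on any further core.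

All the compounds shown carry either allyl or phenyl on that ring nitrogen, so it remains open how a benzyl group, or a longer chain ending in an amine, would read there. Also open is what the carbonyl and the oxime each contribute, since the two cores differ in more than one place and no pair shown separates them.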